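The source may report more compounds than this note shows. Statements on the series, on what has been measured and on what is new or still open speak of the compounds shown alone.

Measured so far:
compound 1 `O=C(Nc1nc(-c2ccccc2)nc2c1nnn2Cc1ccccc1)C1CCCCC1` — 12 nM
compound 2 `COc1ccccc1C(=O)Nc1nc(-c2ccccc2)nc2c1nnn2Cc1ccccc1` — 1520 nM

In an assay (strain Wistar) for displacement of a labelled ligand from adenosine receptor A1 (Rattus norvegicus), read by scintillation counting (on this read-out lower numbers stand for stronger inhibition and higher numbers for weaker inhibition), compound 2 gives 1520 nM, the highest of the two numbers, while compound 1 gives 12 nM. Compound 3 `O=C(Nc1nc(-c2ccccc2)nc2c1nnn2Cc1ccccc1)c1ccoc1` differs from compound 2 by furan-3-yl in place of 2-methoxyphenyl on a carbonyl carbon. Among the compounds with values here, the one measured step at this place, a 130-fold higher number from compound 1 to compound 2 (2.10 log units; beyond the scatter), shows that the group on the carbonyl carbon can shift this assay by a large amount, but no measured step tells how a furan-3-yl group fares. Compound 3 is therefore expected, with wide uncertainty, to come in somewhat lower than compound 2, a step of a 10-fold lower number from compound 2 to compound 3 (1.01 log units; beyond the scatter), at an estimated 150 nM within a range of 30 nM to 800 nM.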

Compound 3, inhibition constant: 10 nM
Estimate against measurement, compound 3: 15-fold (1.18 log units) above; the measured number lies below the stated range.
By their numbers in this assay, from the lowest: compounds 3 and 1 (each within the scatter of the next); then compound 2.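

Furan-3-yl in place of 2-methoxyphenyl on the carbonyl carbon gives a 150-fold lower number from compound 2 to compound 3 (2.18 log units; beyond the scatter) in this assay and shows that an aromatic ring at this position does not by itself bring a high number. Furan-3-yl in place of cyclohexyl gives a 1.2-fold lower number from compound 1 to compound 3 (0.08 log units; within the scatter) and so leaves the two groups indistinguishable in this read-out. Nothing measured here explains the gap between furan-3-yl and 2-methoxyphenyl.

The compounds shown leave open whether the high number of compound 2 goes with the methoxy group or with the six-membered ring itself. Unsubstituted phenyl and furan-2-yl on the same carbonyl carbon remain open too.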